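The source may hold more compounds than are shown below. What is called first, only, known or untested is meant among the compounds shown, and "the series" means these compounds.

This piece follows one change made to compound 2 `COc1cc(C(N)=O)cc2nc(NC(=O)c3ccccn3)n(CCCNC(=O)OCc3ccccc3)c12`, which was tested in an assay for activation of interferon regulatory factor 3 (Homo sapiens), read by a luciferase reporter, with a stated time of 20 h; a higher number here means that more compound is needed for the effect, a lower number that less compound is needed. In that assay compound 2 gives > 100000 nM, which is a limit of the assay rather than a number. Compound 1 `CCCn1c(NC(=O)c2ccccn2)nc2cc(C(N)=O)cc(OC)c21` gives > 100000 nM in this assay, again only a limit. Compound 3 `COc1cc(C(N)=O)cc2nc(NC(=O)CCc3ccccc3)n(CCCNC(=O)OCc3ccccc3)c12` gives > 100000 nM in this assay, also a limit. Two steps connect these three compounds: a step that the two limits leave unreadable from compound 1 to compound 2, and a step that the two limits leave unreadable from compound 2 to compound 3. Neither step can be read, because of the limit of > 100000 nM in this assay, at which 3 of the 3 values shown sit.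

The new compound is compound 4 `COc1cc(C(N)=O)cc2nc(NC(=O)c3ccccn3)n(CCCCNC(=O)OC(C)(C)C)c12`. It differs from compound 2 by ((tert-butoxycarbonyl)amino)methyl in place of (benzyloxycarbonyl)amino on a saturated chain carbon, three bonds along the chain from an aromatic nitrogen. Going by the values given here, the only measured steps that bear on this change are the two just named, and both are unreadable, so they offer no direction and no size for the coming step in this assay. With every neighbour sitting at the same limit, the plain expectation is that compound 4 will also return a limit rather than a number, though a true value cannot be ruled out. Compound 4 is therefore expected at about 150000 nM, with a range from 40000 nM to 500000 nM. The expected step from compound 2 to compound 4 is a step that the limit leaves unreadable from compound 2 to compound 4, meaning no change that could be read beyond the limit.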

Compound 4, half-maximal effective concentration: > 100000 nM
Compound 4 ended at the assay's limit; the forecaster's own chance of this, stated with the estimate: 85%; the middle value is on the limit's open side.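

Neither the change from compound 2 to compound 4 nor the one from compound 1 to compound 4 gives a step that can be read, because each compound gives only a limit rather than a number: the limit of > 100000 nM in this assay, at which 4 of the 4 values shown sit.

The compounds shown leave open how far apart compound 1, compound 2, compound 3 and compound 4 truly lie, and whether any change to them would give a measurable value in this assay.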